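The source may hold more compounds than are shown below. What is called first, only, known or untested is meant among the compounds shown, and "the series" means these compounds.

Compound 1 `CCCCCCC(CCO)n1cnc2c(Cl)nc(F)nc21` and compound 2 `CCCCCCCC(CCO)n1cnc2c(Cl)nc(F)nc21` are built on one core, while compound 3 `CCCCCCC[C@@H](CCO)n1cnc2c(Cl)ncnc21` and compound 4 `CCCCCCCC[C@@H](CCO)n1cnc2c(Cl)ncnc21` are built on another; the difference between the two cores is not broken down here. Among the compounds with values here, each carries a long saturated chain on a ring nitrogen together with a hydroxyethyl arm, and within each pair the only change is a methyl added along that chain.

In a functional assay on HCT-116 cells (Homo sapiens) for antiproliferative activity, read by MTT assay, with a stated time of 48 h (on this read-out higher numbers stand for weaker inhibition and lower numbers for stronger inhibition), compound 1 gives 9960 nM, and compound 2 gives 17600 nM. In this assay compound 3 gives 10700 nM, a number that sits within the scatter of both compound 1 and compound 2.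

The change from compound 1 to compound 2 is methyl in place of hydrogen on a saturated chain carbon, seven bonds along the chain from an aromatic nitrogen and it made a 1.8-fold higher number from compound 1 to compound 2 (0.25 log units; within the scatter). Compound 4 arises from compound 3 by methyl in place of hydrogen on a saturated chain carbon, eight bonds along the chain from an aromatic nitrogen. This is the same kind of change, not the same one: in the first pair the methyl sits seven bonds along the chain from an aromatic nitrogen, in the second eight bonds along the chain from an aromatic nitrogen.

Because the earlier step of a 1.8-fold higher number from compound 1 to compound 2 (0.25 log units; within the scatter) stayed within the scatter, compound 4 is expected to land close to compound 3, with an estimated step of a 1.5-fold higher number from compound 3 to compound 4 (0.17 log units; within the scatter). The estimate for compound 4 in this assay is 16000 nM, expected to fall between 7000 nM and 38000 nM.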

Compound 4, half-maximal inhibitory concentration: 3400 nM
Estimate against measurement, compound 4: 4.7-fold (0.67 log units) above, outside the stated range (below it).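

In this assay the added methyl on the core of compound 3 brought a 3.1-fold lower number from compound 3 to compound 4 (0.50 log units; beyond the scatter) and thus stronger inhibition of cell growth, a step larger than repeat measurements would normally produce. Set beside the earlier pair, this shows that the effect of lengthening the chain by a methyl did not carry over unchanged from one core to the other: the same change on two cores in this assay, a 1.8-fold higher number (0.25 log units; within the scatter) from compound 1 to compound 2 and a 3.1-fold lower number (0.50 log units; beyond the scatter) from compound 3 to compound 4, 5.6-fold (0.75 log units) apart, beyond the scatter of two such steps. It does not show what lies behind that gap: the cores differ, the methyl sits at a different place along the chain in each pair, and each step rests on a single pair of compounds, so the core and the chain length cannot be separated here.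

The compounds shown leave open whether a still longer chain would keep lowering the number on the core of compound 3, and how the chain of compound 4 would behave on the core of compound 1. They also leave open what an amine or a carboxylic acid would do in place of the hydroxyl group at the end of the hydroxyethyl arm.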